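The compounds below may be only part of what the source reports. "The series", "measured", "known", "first", "only" and "open" are said of these compounds alone.

Shifting a methoxy group on a thiophene-free scaffold? No—simply: Shifting the methoxy group from compound 2 to compound 3

Measured compounds:
compound 1, `CC(C)(C)Cc1c(/C=C/c2ccc(Cl)cc2)sc(N)c1C(=O)c1ccc(Cl)cc1`, 11%
compound 2, `COc1cccc(-c2sc(N)c(C(=O)c3ccc(Cl)cc3)c2CC(C)(C)C)c1`, 1%

In an assay on CHO cells for displacement of a labelled ligand from adenosine receptor A3 (Homo sapiens), read by scintillation counting, tested at 10 uM (on this read-out lower numbers stand for less inhibition and higher numbers for more inhibition at the one concentration tested (going by the name of the read-out)), compound 2 gives the lower of the two numbers recorded, and its nearest neighbour is compound 1: the change a number 10 percentage points lower from compound 1 to compound 2 (within the scatter) lies within the scatter, so the two values cannot be told apart. Compound 3, `COc1ccccc1-c1sc(N)c(C(=O)c2ccc(Cl)cc2)c1CC(C)(C)C`, differs from compound 2 only in that (2-methoxyphenyl in place of 3-methoxyphenyl on an aromatic carbon). For the measured compounds named here, the single measured step bears on this only loosely, since it exchanged a different group altogether and itself stayed within the scatter. With both measured compounds sitting at low inhibition and no step beyond the scatter anywhere in the set, the expectation for compound 3 is no movement beyond the scatter, a number 4 percentage points higher from compound 2 to compound 3 (within the scatter). Compound 3 is therefore estimated at 5%, with a range from -5% to 20%.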

Compound 3, a percentage reported as inhibition, at one concentration (the size of the read-out at that concentration, not a potency): 1%
Compound 3: the middle estimate sits 4 percentage points above what was measured; low and high end bracket the measured number.
By their numbers in this assay, from the lowest: compounds 2, 3 and 1 (each within the scatter of the next).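

For the compounds shown here, at the aromatic carbon next to the ring sulfur, this is the first comparison in which only the place of the methoxy group on the phenyl ring changes, and in this assay it gives no change at the digits printed from compound 2 to compound 3 (within the scatter). Replacing the 2-(4-chlorophenyl)ethenyl group with 2-methoxyphenyl gives a number 10 percentage points lower from compound 1 to compound 3 (within the scatter), so neither methoxyphenyl group can be told apart from the 2-(4-chlorophenyl)ethenyl group at this position. Nothing in the available data offers an explanation for these readings.

From the compounds shown here alone, all three compounds share the neopentyl, amino and (4-chlorophenyl)carbonyl groups, so the effect of changing any of these remains open. Going by these compounds, it also remains open whether a carboxylic acid, a piperidine or a longer alkyl chain at this carbon would move the number beyond the scatter in this assay.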